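Fluorophenyl positional isomers on the shared core

The source may hold more compounds than are shown below. What is called first, only, known or untested is meant among the compounds shown, and "the series" means these compounds.

Compound 2 `O=C(N[C@H]1CCC[C@H](NC(=O)c2ccccc2F)C1)c1cccc(Cl)c1` gives 760 nM in an assay on HEK293 cells for displacement of a labelled ligand from metabotropic glutamate receptor 5 (Homo sapiens), read by scintillation counting, with a stated time of 60 min (on this read-out higher numbers stand for weaker inhibition and lower numbers for stronger inhibition), the higher of the two numbers obtained so far; compound 1 `O=C(N[C@H]1CCC[C@H](NC(=O)c2cccc(Cl)c2)C1)c1ccncc1` gives 445 nM, and the two lie within the scatter of each other, so no order between them can be claimed. Going by the values given here, the one measured step, a 1.7-fold higher number from compound 1 to compound 2 (0.23 log units; within the scatter), is the only comparison available and it stays within the scatter. Compound 3 `O=C(N[C@H]1CCC[C@H](NC(=O)c2cccc(Cl)c2)C1)c1ccc(F)cc1` differs from compound 2 by 4-fluorophenyl in place of 2-fluorophenyl on a carbonyl carbon. Among the compounds with values here, no measured step exchanges one fluorophenyl for another, so nothing observed bears directly on this change; the single step seen on this carbonyl carbon, from compound 1 to compound 2, was small. For compound 3 the expected step of a 1.3-fold lower number from compound 2 to compound 3 (0.10 log units; within the scatter) is therefore taken as none beyond the scatter. Compound 3 is accordingly estimated at 600 nM in this assay, within the range 250 nM to 1500 nM.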

Compound 3, inhibition constant: 492 nM
Estimate against measurement, compound 3: 1.2-fold (0.09 log units) above; the measured number falls inside the stated range.
By their numbers in this assay, from the lowest: compounds 1, 3 and 2 (each within the scatter of the next).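

In this assay, going by these compounds alone, the first exchange of one fluorophenyl for another gives a 1.5-fold lower number from compound 2 to compound 3 (0.19 log units; within the scatter), so the change from 2-fluorophenyl to 4-fluorophenyl on this carbonyl carbon supports no order between the two isomers. The exchange of pyridin-4-yl for 4-fluorophenyl at the same place gives a 1.1-fold higher number from compound 1 to compound 3 (0.04 log units; within the scatter), so pyridin-4-yl, 2-fluorophenyl and 4-fluorophenyl now all lie within the scatter of one another at this position, and neither the place of the fluorine nor a ring of carbon only separates these compounds. No supporting evidence bears on these results.

From the compounds shown here alone, whether an amine, a carboxylic acid or a longer chain on this carbonyl carbon would give a step beyond the scatter remains open. Also open, going by these compounds, is whether the fluorophenyl isomers would still read alike with a different group elsewhere on the shared core.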